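Swapping the amide aryl ring for a saturated spiro group

This account rests on a few compounds, and the source may have more. Where it says the series, first, only, none or still open, it means among the compounds named here.

Measured compounds:
compound 1 `O=C(c1cccc(F)c1)N1CC(c2nc(-c3cccc(Cl)c3)no2)C1` with 780 nM
compound 2 `Cc1cccc(-c2noc(C3CN(C(=O)c4cccc(F)c4)C3)n2)c1` with 2100 nM

In an assay on HEK293 cells for negative allosteric modulation of metabotropic glutamate receptor 5 (Homo sapiens), read by FLIPR (a lower number here means a stronger inhibitor, a higher number a weaker inhibitor), compound 1 has the lower of the two numbers; the step of a 2.7-fold higher number from compound 1 to compound 2 (0.43 log units; beyond the scatter) comes from a methyl in place of chloro on an aromatic carbon. Compound 3 `O=C(C1CCC2(CCC2)CC1)N1CC(c2nc(-c3cccc(Cl)c3)no2)C1` differs from compound 1 at the other end of the core: a group of 9 heavy atoms (9 carbon; one four-membered non-aromatic ring of carbon only, one six-membered non-aromatic ring of carbon only) in place of a group of 7 heavy atoms (6 carbon, 1 fluorine; one six-membered aromatic ring of carbon only), on a carbonyl carbon. Within the data shown here, the one measured step changes a different position, so nothing here bears directly on this swap. Without such a comparison, a modest weakening is expected, the step of a 1.9-fold higher number from compound 1 to compound 3 (0.28 log units; within the scatter), so compound 3 is estimated at 1500 nM, in the range 400 nM to 6000 nM.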

Compound 3, half-maximal inhibitory concentration: > 10000 nM
Compound 3: no number, only a limit; the forecaster's own chance of this, stated with the estimate: 10%; middle value at least 6.6-fold (0.82 log units) away from the limit.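

The 3-fluorophenyl group on the carbonyl carbon turns out to matter, which the earlier change on the aromatic carbon could not show. In this assay, the saturated spiro group gives an at least 12-fold higher number from compound 1 to compound 3 (1.10 log units; beyond the scatter), a large step. The result for compound 3 is a limit of the assay, not a number: the limit of > 10000 nM in this assay, at which 1 of the 3 values shown sits.

Going by these compounds, whether a plain cyclohexyl group or a pyridine ring on this carbonyl carbon would keep the inhibition remains open. So does whether the step follows from losing the aromatic ring or from adding the four-membered ring.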